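A few compounds are considered here, and "the series" means these few. Any claim that something is new, unique, unknown or untested is made for them only; others in the source may bear on it.

Notes on the series in a functional assay on B16 cells (Mus musculus) for inhibition; on this read-out lower numbers stand for stronger inhibition and higher numbers for weaker inhibition. Compound 2 (`CC(C)CN(CC(=O)N(CC(C)C)NC(=O)OCc1ccccc1)/N=C/c1cccc(B(O)O)c1`) gives 53900 nM. Compound 1 (`CC(C)CN(CC(=O)N(Cc1ccccc1)NC(=O)OCc1ccccc1)/N=C/c1ccccc1B(O)O`) gives 33500 nM, within the scatter of compound 2, so these two cannot be ordered. Compound 3 (`CC(C)CN(NC(=O)OCc1ccccc1)C(=O)CN(Cc1ccccc1)/N=C/c1cccc(B(O)O)c1`) gives 20400 nM, and the measured change is a 2.6-fold lower number from compound 2 to compound 3 (0.42 log units; beyond the scatter), modest but beyond the scatter.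

The next change leads to compound 4 (`CC(C)CN(CC(=O)N(Cc1ccccc1)NC(=O)OCc1ccccc1)/N=C/c1cccc(B(O)O)c1`): phenyl in place of isopropyl on a saturated chain carbon bound to an amide-type nitrogen. This places phenyl in place of isopropyl on a saturated chain carbon bound to an amide-type nitrogen. Among the compounds with values here, the one measured single-place step makes the same swap at a different place, on a saturated chain carbon bound to an amine nitrogen, so it is only an indirect guide. Compound 1, at 33500 nM, also carries phenyl at the amide-type place but differs from compound 4 elsewhere. With a 2.6-fold lower number from compound 2 to compound 3 (0.42 log units; beyond the scatter) as the guide, a modest lowering in this assay is expected, possibly not clearing the scatter. The estimated step is a 1.9-fold lower number from compound 2 to compound 4 (0.28 log units; within the scatter). For compound 4 the expected value is 28000 nM, with an estimated range of 14000 nM to 55000 nM.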

Compound 4, half-maximal inhibitory concentration: 20500 nM
Compound 4: middle estimate off by 1.4-fold (0.14 log units), on the high side; the range from low to high includes it.
By their numbers in this assay, from the lowest: compounds 3, 4, 1 and 2 (each within the scatter of the next, the first and the last beyond it).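

In this assay, phenyl in place of isopropyl on a saturated chain carbon bound to an amide-type nitrogen gives a 2.6-fold lower number from compound 2 to compound 4 (0.42 log units; beyond the scatter), so this swap now has a direct reading at this place and matches the printed size of a 2.6-fold lower number from compound 2 to compound 3 (0.42 log units; beyond the scatter), the step at the amine-bound place. The change of the boron-bearing aromatic group on the carbon with a double bond to nitrogen gives a 1.6-fold lower number from compound 1 to compound 4 (0.21 log units; within the scatter), so that pair cannot be ordered. No measurement here accounts for either step.

On these data alone, whether phenyl at both chain places would go further than either single swap remains open. So does the outcome of cyclohexyl or a longer chain at the amide-type place, or of a carboxylic acid in place of the boron-bearing group.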